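Working notes: paw edema inhibition, compound 1 to compound 3

The compounds below may be only part of what the source reports. "The series", "measured", "known", "first", "only" and "open" are said of these compounds alone.

Measured compounds:
compound 1 `CC1=NN(C(=O)c2cc3ccccc3oc2=O)C(=O)C1CNc1cccc(S(N)(=O)=O)c1`: 79.9%
compound 2 `CC1=NN(C(=O)c2cc3ccccc3oc2=O)C(=O)C1CNc1c(O)cc(S(=O)(=O)O)c2ccccc12`: 45.3%

In a functional assay on the whole organism for inhibition, with Rattus norvegicus as the target, read by paw edema, with stated times of 1 h and 6 h, at a dose of 0.03 mg/kg by the oral route (a higher number here means more inhibition at the dose given (going by the name of the read-out), a lower number less inhibition), compound 1 gives 79.9%, the higher of the two numbers; compound 2 gives 45.3%, lower by a margin beyond the scatter. Within the data shown here, no step between measured compounds that differ in one place is available, so the effect of a single exchange is untested here.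

Compound 3 `COc1ccc(NCC2C(=O)N(C(=O)c3cc4ccccc4oc3=O)N=C2C)cc1` is compound 1 with 4-methoxyphenyl in place of 3-sulfamoylphenyl on an amine nitrogen. A downward step beyond the scatter is expected for a number 24.9 percentage points lower from compound 1 to compound 3 (beyond the scatter). Compound 3 is therefore expected to give about 55%, with a range from 35% to 75%.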

Compound 3, a percentage reported as inhibition, in the whole organism at one dose (the size of the read-out at that dose, not a potency): 55.1%
Compound 3: the middle estimate sits 0.1 percentage points below what was measured, within the range that was stated.
By their numbers in this assay, from the lowest: compounds 2 and 3 (each within the scatter of the next); then compound 1.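

Among these compounds, the step of a number 24.8 percentage points lower from compound 1 to compound 3 (beyond the scatter) in this assay is the first single exchange that can be read: 4-methoxyphenyl in place of 3-sulfamoylphenyl on an amine nitrogen. The position therefore responds to the aryl group it carries, yet inhibition persists at this dose without the sulfamoyl group. Nothing available bears on the reason for this step.

The exchange alters both the substituent and its place on the ring, so the compounds shown do not separate these two changes. An unsubstituted phenyl, 3-methoxyphenyl or 4-sulfamoylphenyl on the same nitrogen would bear on that question.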